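A few compounds are considered here, and "the series" means these few. Any claim that something is new, unique, unknown or untested is made for them only; others in the source may bear on it.

Compound 3 `Cc1ccc(S(=O)(=O)NC(C)(C)C)cc1C#Cc1cc(Cl)ccc1OCC(=O)O` stands second highest of the three numbers in an assay on CHO cells for displacement of a labelled ligand from prostaglandin D2 receptor 2 (Homo sapiens), read by scintillation counting (on this read-out lower numbers stand for stronger inhibition and higher numbers for weaker inhibition), where compound 3 gives 5 nM in this measure. Compound 1 `CNS(=O)(=O)c1ccc(C)c(C#Cc2cc(Cl)ccc2OCC(=O)O)c1` gives 10 nM in this assay and compound 2 `Cc1ccc(S(=O)(=O)N2CCCCC2C)cc1C#Cc1cc(Cl)ccc1OCC(=O)O` gives 1.9 nM there. Compound 4 `Cc1ccc(S(=O)(=O)N(C)CCN(C)C)cc1C#Cc1cc(Cl)ccc1OCC(=O)O` differs from compound 3 in one place only, namely (2-(dimethylamino)ethyl)(methyl)amino in place of (tert-butyl)amino on a sulfonyl sulfur as counted from the two structures. Among the compounds with values here, three measured steps bear on changes at this sulfonyl sulfur: a 5.3-fold lower number from compound 1 to compound 2 (0.72 log units; beyond the scatter) is the largest, while a 2.0-fold lower number from compound 1 to compound 3 (0.30 log units; within the scatter) and a 2.6-fold higher number from compound 2 to compound 3 (0.42 log units; beyond the scatter) are smaller. Within these three compounds a larger group on that sulfur has given a lower or an unchanged number, so a small downward step is expected for compound 4, a 1.3-fold lower number from compound 3 to compound 4 (0.10 log units; within the scatter) in this assay being the estimate. For compound 4 the expected value in this assay is 4 nM with a range from 1.5 nM to 12 nM around it.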

Compound 4, inhibition constant: 369 nM
Compound 4: middle estimate off by 92-fold (1.96 log units), on the low side, outside the stated range (above it).
By their numbers in this assay, from the lowest: compound 2; then compounds 3 and 1 (each within the scatter of the next); then compound 4.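

In this assay the change gives a 74-fold higher number from compound 3 to compound 4 (1.87 log units; beyond the scatter) and a 190-fold higher number from compound 2 to compound 4 (2.29 log units; beyond the scatter) and a 37-fold higher number from compound 1 to compound 4 (1.57 log units; beyond the scatter) and leaves compound 4 with the highest number of the four. The earlier compounds shown here suggested that a larger group on a sulfonyl sulfur gives a lower or unchanged number, but compound 4 goes against this, so the position is far less forgiving than they implied. Nothing available here explains the loss.

From the compounds shown here alone, whether it follows the dimethylamino end or the chain itself stays open. A 2-methoxyethyl or plain butyl chain on that sulfonamide nitrogen could separate the two.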